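Chloro in place of acetyl: expected tolerance of compound 4

This account rests on a few compounds, and the source may have more. Where it says the series, first, only, none or still open, it means among the compounds named here.

Compound 1 `CC(=O)N1CCCCC1C(NC(=O)C(=O)Nc1ccc(Cl)cc1)c1nc(C)c(CCO)s1`: in an ADME assay on TZM-b1 cells (Homo sapiens) for cytotoxicity, read by XTT assay, with a stated time of 3 days (a higher number here means that more compound is tolerated, a lower number that less compound is tolerated), compound 1 gives > 84000 nM, which is a limit of the measurement.
Compound 2 `Cc1nc(C(NC(=O)C(=O)Nc2ccc(F)cc2F)C2CCCCN2)sc1CCO`: in this assay compound 2 gives > 84000 nM, again a limit.
Compound 3 `CC(=O)c1ccc(NC(=O)C(=O)NC(c2nc(C)c(CCO)s2)C2CCCCN2)cc1`: in this assay compound 3 gives > 77300 nM, also a limit.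

None of the three compounds reached a measurable value, so each result only says that the cells tolerated the highest amount tested. Compound 3 sits at the limit of > 77300 nM in this assay, at which 1 of the 3 values shown sits, while the other two sit at the limit of > 84000 nM in this assay, at which 2 of the 3 values shown sit. For the measured compounds named here, the one comparable step, a step that the two limits leave unreadable from compound 2 to compound 3, is therefore unreadable.

Compound 4 `Cc1nc(C(NC(=O)C(=O)Nc2ccc(Cl)cc2)C2CCCCN2)sc1CCO` differs from compound 3 by chloro in place of acetyl on an aromatic carbon. Going by the values given here, no measured step gives a readable size for any change here, so in this assay no step beyond the scatter is expected, and the estimate for the step is a step that the limit leaves unreadable from compound 3 to compound 4. Compound 4 is expected to give about 84000 nM, with a range from 30000 nM to 250000 nM, most likely again only as a limit.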

Compound 4, half-maximal cytotoxic concentration: 32800 nM
Estimate against measurement, compound 4: 2.6-fold (0.41 log units) above; measured number inside the range.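

Chloro in place of acetyl on this aromatic carbon gives the first measurable number in the series, an at least 2.3-fold lower number from compound 3 to compound 4 (0.37 log units; beyond the scatter) in this assay, and this size is only a minimum because compound 3 stops at a limit: the limit of > 77300 nM in this assay, at which 1 of the 4 values shown sits. Compound 4 also differs from its other neighbours, with an at least 2.5-fold lower number from compound 2 to compound 4 (0.40 log units; beyond the scatter) for 4-chlorophenyl in place of 2,4-difluorophenyl and an at least 2.5-fold lower number from compound 1 to compound 4 (0.40 log units; beyond the scatter) for hydrogen in place of acetyl on the ring nitrogen, and both sizes are minimums because compound 1 and compound 2 stop at a limit: the limit of > 84000 nM in this assay, at which 2 of the 4 values shown sit. The 4-chlorophenyl group alone therefore does not bring a measurable number, as compound 1 carries it and still gives only a limit.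

Going by these compounds, whether methoxy or a carboxylic acid on the same aromatic carbon would also lower the number stays open. So do the true sizes of these steps, and whether a longer acyl chain on the ring nitrogen would act as acetyl does.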